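The compounds below may be only part of what the source reports. "The series", "measured", "known", "first", "only" and "open" are said of these compounds alone.

Measured compounds:
compound 1 `N[C@@H](COP(=O)(O)OCCCOC(=O)CCc1ccccc1OCCCCCCOc1ccccc1)C(=O)O` — 0.071
compound 2 `N[C@@H](COP(=O)(O)OCCCOC(=O)CCc1ccccc1OCc1cccc(Cc2ccccc2)c1)C(=O)O` — 0.077

In an assay on cells for activation of probable G-protein coupled receptor 34 (Mus musculus), with a stated time of 1 h (a higher number here means a larger maximal response, a lower number a smaller maximal response), compound 1 gives 0.071, and in this assay compound 2 gives 0.077. These two values lie within the usual scatter of each other, so nothing separates compound 2 from compound 1 on these numbers; both show only a small maximal response. Compound 3 `Cc1cccc(Oc2cccc(COc3ccccc3CCC(=O)OCCCOP(=O)(O)OC[C@H](N)C(=O)O)c2)c1` shares the core of compound 2 and differs from it in one place: 3-methylphenoxy in place of benzyl on an aromatic carbon. Going by the values given here, no measured pair in this set shows the effect of such a change, so the expectation for compound 3 rests on the two small values alone. The step from compound 2 to compound 3 in this assay is expected to be small, a number 0.0030 higher from compound 2 to compound 3 (within the scatter), in neither direction beyond the scatter. Compound 3 is therefore estimated to give 0.08, within a range from 0.03 to 0.2.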

Compound 3, intrinsic activity: the largest response reached, as a fraction of the reference agonist's: 0.29
Beside the measured number, compound 3's estimate is 0.21 below it, outside the stated range (above it).
By their numbers in this assay, from the lowest: compounds 1 and 2 (each within the scatter of the next); then compound 3.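

In this assay, putting 3-methylphenoxy in place of benzyl on this aromatic carbon, meta to a large group, gives a number 0.21 higher from compound 2 to compound 3 (beyond the scatter). Going by these compounds alone, this is the first sign in the set that the group at this position can shift the maximal response, which the two earlier values, lying within the scatter of each other, could not show. The change brings in an oxygen and a methyl together, and nothing measured here explains the step or assigns it to either part.

An unsubstituted phenoxy group or a benzyl group carrying a methyl would be needed to separate the contributions of the oxygen and the methyl. As far as these compounds go, how far the maximal response would move with an ethyl or a chlorine in place of this methyl also remains open.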